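The source may report more compounds than this note shows. Statements on the series, on what has been measured and on what is new or still open speak of the compounds shown alone.

Measured in a functional assay on BaF3 cells (Mus musculus) for antiproliferative activity, read by CCK-8 assay and cell counting, with a stated time of 76 h; a lower number here means a stronger inhibitor, a higher number a weaker inhibitor:
- compound 1 `COc1cc2nccc(Oc3ccc(Nc4nn(C)cc4C(=O)N4CCCCC4)cc3)c2cc1C(N)=O`: 5650 nM
- compound 2 `COc1cc2nccc(Oc3ccc(Nc4nn(C)cc4C(=O)NCC4CCCO4)cc3)c2cc1C(N)=O`: > 10000 nM
- compound 3 `COc1cc2nccc(Oc3ccc(Nc4nn(C)cc4C(=O)NCC4CCCCC4)cc3)c2cc1C(N)=O`: > 10000 nM

The entry for compound 2 is a limit of the assay, not a number. The entry for compound 3 is also only a limit, and compound 3 stands at the limit of > 10000 nM in this assay, at which 2 of the 3 values shown sit.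

Compound 4 `COc1cc2nccc(Oc3ccc(Nc4nn(C)cc4C(=O)NC4CCCC4)cc3)c2cc1C(N)=O` differs from compound 3 by cyclopentyl in place of cyclohexylmethyl on an amide-type nitrogen.

Within the data shown here, three measured steps bear on this change. They are an at least 1.7-fold higher number from compound 1 to compound 2 (0.24 log units; that floor lies within the scatter), an at least 1.7-fold higher number from compound 1 to compound 3 (0.24 log units; that floor lies within the scatter) and a step that the two limits leave unreadable from compound 2 to compound 3. None of them fixes a size, and the last shows nothing about how the two ring-bearing groups compare.

Compound 4 carries cyclopentylamino on the carbonyl carbon, which resembles the (cyclohexylmethyl)amino of compound 3 more than the piperidin-1-yl of compound 1. Taking an at least 1.7-fold higher number from compound 1 to compound 3 (0.24 log units; that floor lies within the scatter) as the guide, a weak result close to the limit is expected in this assay, possibly again reported only as a limit. The expected change is small, and its direction is uncertain: an at least 1.2-fold lower number from compound 3 to compound 4 (0.09 log units; that floor lies within the scatter). Compound 4 is estimated at 8000 nM, with an expected range from 3000 nM to 15000 nM.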

Compound 4, half-maximal inhibitory concentration: > 10000 nM
Compound 4: no number, only a limit; the forecaster's own chance of this, stated with the estimate: 50%; middle value at least 1.2-fold (0.09 log units) away from the limit.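

In this assay, cyclopentyl on the amide-type nitrogen gives no readable value, just as cyclohexylmethyl and (oxolan-2-yl)methyl gave none, so a third group at this place ends at the same limit: the limit of > 10000 nM in this assay, at which 3 of the 4 values shown sit. Against compound 1, the change to cyclopentylamino gives an at least 1.7-fold higher number from compound 1 to compound 4 (0.24 log units; that floor lies within the scatter), so this step, like the two earlier ones from compound 1, fixes no size beyond the scatter. The steps to compound 4 from compound 2 and from compound 3 cannot be read, as both ends of each are limits.

Still open, as far as these compounds go, is how far compound 2, compound 3 and compound 4 lie past the limit, and so whether they truly differ from compound 1 or from one another. A morpholin-4-yl or dimethylamino group on the carbonyl carbon would show whether compound 1 stands alone among such amides.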